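Removing an Ethyl Group from a Fatty Acid Receptor Agonist

This account rests on a few compounds, and the source may have more. Where it says the series, first, only, none or still open, it means among the compounds named here.

Compound 1 `Cc1cc(OCC(C)C)cc(C)c1-c1cccc(COc2ccc(OCC(=O)O)c(F)c2)c1`: "not determined" (no result reported) in a functional assay on CHO cells for agonist activity at Free fatty acid receptor 1 (Homo sapiens), read by FLIPR and calcium flux; on this read-out higher numbers stand for an effect only at larger amounts of compound and lower numbers for an effect already at smaller amounts
Compound 2 `CCOc1cc(C)c(-c2cccc(COc3ccc(OCC(=O)O)c(F)c3)c2)c(C)c1`: 65.9 nM in this assay

Compound 2 stands alone with a number in this assay; compound 1 has none. Compound 3 `Cc1cc(O)cc(C)c1-c1cccc(COc2ccc(OCC(=O)O)c(F)c2)c1` differs from compound 2 by hydrogen in place of ethyl on an oxygen on an aromatic ring. Among the compounds with values here, no measured pair shows this change, so the size of the step is open. Given that compound 2 gives 65.9 nM in this assay, a shift toward an effect only at larger amounts is expected, beyond the usual scatter, with an expected step of a 3.8-fold higher number from compound 2 to compound 3 (0.58 log units; beyond the scatter). Compound 3 is therefore estimated at 250 nM, within a range of 80 nM to 900 nM.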

Compound 3, half-maximal effective concentration: 110 nM
The estimate for compound 3 lay 2.3-fold (0.36 log units) above the measured number; measured number inside the range.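

In this assay, replacing ethoxy with hydroxy on the aromatic ring gives a 1.7-fold higher number from compound 2 to compound 3 (0.22 log units; within the scatter), so compound 2 and compound 3 stand level on this read-out. At this position, the ethyl group is therefore not needed to keep the number in this range. No available evidence explains this result.

As far as these compounds go, compound 1, with its longer isobutoxy chain, carries no number, so how chain length plays out here stays open. From the compounds shown here alone, how a methoxy group or an amine at this place would read in this assay also remains unknown.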